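This account rests on a few compounds, and the source may have more. Where it says the series, first, only, none or still open, it means among the compounds named here.

Compound 1 `O=C1C[C@H](OCc2cn(Cc3ccccc3)nn2)[C@H]2CO[C@@H]1O2` gives in a functional assay on MDA-MB-231 cells (Homo sapiens) for cytotoxicity, read by MTT assay, with a stated time of 48 h (a lower number here means a stronger inhibitor, a higher number a weaker inhibitor), only a limit, > 50000 nM. Compound 2 `CCCCCCCCn1cc(CO[C@H]2CC(=O)[C@@H]3OC[C@H]2O3)nn1` likewise gives only a limit in this assay, > 50000 nM. Compound 3 `COc1ccc(Cn2cc(CO[C@H]3CC(=O)[C@@H]4OC[C@H]3O4)nn2)cc1` gives a number in this assay, 34800 nM.

Compound 3 thus holds the only number among these three, the other two sitting at the limit of > 50000 nM in this assay, at which 2 of the 3 values shown sit. The step to compound 4 `O=C1C[C@H](OCc2cn(Cc3ccc([N+](=O)[O-])cc3)nn2)[C@H]2CO[C@@H]1O2` is nitro in place of methoxy on an aromatic carbon. For the measured compounds named here, the single earlier step at this same aromatic carbon, an at least 1.4-fold lower number from compound 1 to compound 3 (0.15 log units; that floor lies within the scatter), ran from a limit to a number, so only a floor for its size is known, and that floor lies within the scatter. The steps a step that the two limits leave unreadable from compound 1 to compound 2 and an at least 1.4-fold lower number from compound 2 to compound 3 (0.15 log units; that floor lies within the scatter) change the group on the chain carbon instead and give no guidance on a swap at the ring. No step beyond the scatter is therefore expected in this assay, a 1.0-fold higher number from compound 3 to compound 4 (0.00 log units; within the scatter). Compound 4 is expected to give about 35000 nM, between 12000 nM and 100000 nM.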

Compound 4, half-maximal inhibitory concentration: 25400 nM
Compound 4: the middle estimate sits 1.4-fold (0.14 log units) above what was measured; low and high end bracket the measured number.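

Setting nitro in place of methoxy on this aromatic carbon gives a 1.4-fold lower number from compound 3 to compound 4 (0.14 log units; within the scatter) in this assay. For the compounds shown here, this is the first step at this position between two real numbers, and it does not tell the two groups apart. Nitro in place of hydrogen gives an at least 1.9-fold lower number from compound 1 to compound 4 (0.29 log units; that floor lies within the scatter), which is only a floor because its starting value is a limit: the limit of > 50000 nM in this assay, at which 2 of the 4 values shown sit.

On these data alone, whether any group on this carbon can move the number beyond the scatter stays open. An amine or a carboxylic acid at this place would test that.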